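A few compounds are considered here, and "the series" means these few. Any claim that something is new, unique, unknown or untested is made for them only; others in the source may bear on it.

Compounds measured in a functional assay on M21 cells (Homo sapiens) for antiproliferative activity, read by sulforhodamine B assay, with a stated time of 48 h; a higher number here means a weaker inhibitor, a lower number a stronger inhibitor:
- compound 1, `CC(C)c1ccccc1OS(=O)(=O)c1ccc(NC(=O)C(C)(C)C)cc1`: 6200 nM
- compound 2, `CCNC(=O)Nc1ccc(S(=O)(=O)Oc2ccccc2C(C)C)cc1`: 4700 nM
- compound 3, `CCCCCNC(=O)Nc1ccc(S(=O)(=O)Oc2ccccc2C(C)C)cc1`: 4600 nM

Compound 3 sits together with the other two: the steps of a 1.3-fold lower number from compound 1 to compound 3 (0.13 log units; within the scatter) and a 1.0-fold lower number from compound 2 to compound 3 (0.01 log units; within the scatter) are both within the scatter, so the three numbers cannot be told apart.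

Compound 4 is `CC(C)c1ccccc1OS(=O)(=O)c1ccc(NC(=O)NCCCCl)cc1`. It differs from compound 3 by chloro in place of ethyl on a saturated chain carbon, three bonds along the chain from an amide-type nitrogen. Going by the values given here, two measured steps bear on this. The chain itself was already varied without effect: a 1.0-fold lower number from compound 2 to compound 3 (0.01 log units; within the scatter). Replacing the whole tert-butyl group by a chain also changed little: a 1.3-fold lower number from compound 1 to compound 3 (0.13 log units; within the scatter). A swap at the end of the chain is therefore expected to give no step beyond the scatter in this assay.

Compound 4 is expected to give 4600 nM, within a range from 2300 nM to 9200 nM. The expected step is no change at the digits printed from compound 3 to compound 4 (within the scatter).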

Compound 4, half-maximal inhibitory concentration: 9300 nM
Compound 4: the middle estimate sits 2.0-fold (0.31 log units) below what was measured; the whole stated range lies below it.
By their numbers in this assay, from the lowest: compounds 3, 2, 1 and 4 (each within the scatter of the next, the first and the last beyond it).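

In this assay, going by these compounds alone, the end of the chain is the first place where a swap goes beyond the scatter: chloro in place of ethyl gives a modest step (a 2.0-fold higher number from compound 3 to compound 4 (0.31 log units; beyond the scatter)). Against the ethylamino and tert-butyl compounds, compound 4 stays within the scatter (a 2.0-fold higher number from compound 2 to compound 4 (0.30 log units; within the scatter); a 1.5-fold higher number from compound 1 to compound 4 (0.18 log units; within the scatter)), so the effect is small and shows only against the pentyl chain. No measurement here explains the step.

A plain propyl chain would separate the role of the chloro from that of chain length. As far as these compounds go, a hydroxyl or an amine at the chain end also remains open.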